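Swapping the naphthyl arm for a trifluoromethylphenyl arm

The source may report more compounds than this note shows. Statements on the series, on what has been measured and on what is new or still open speak of the compounds shown alone.

Of the compounds shown here, two sharing one core have been tested in a functional assay on NCI-H322M cells (Homo sapiens) for inhibition, read by sulforhodamine B assay, with a stated time of 48 h, tested at 10 uM; on this read-out higher numbers stand for more inhibition at the one concentration tested (going by the name of the read-out) and lower numbers for less inhibition. Compound 1 `c1ccc2c(-c3cn4ccnc4c(-c4ccc5ncn(C6CCCCC6)c5c4)n3)cccc2c1` gives 4.74% in this assay, and compound 2 `CC(=O)c1ccc(-c2cn3ccnc3c(-c3ccc4ncn(C5CCCCC5)c4c3)n2)cc1` gives 1.19%. For the measured compounds named here, compound 1 holds the higher of the two numbers, but the single step available, a number 3.6 percentage points lower from compound 1 to compound 2 (within the scatter), is within the scatter, so the two read as the same low level of inhibition.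

Compound 3 `FC(F)(F)c1cccc(-c2cn3ccnc3c(-c3ccc4ncn(C5CCCCC5)c4c3)n2)c1` is not yet measured. It differs from compound 1 by 3-(trifluoromethyl)phenyl in place of naphthalen-1-yl on an aromatic carbon. Going by the values given here, the one step already seen on this position, from compound 1 to compound 2, also exchanged the aromatic group on this same carbon and produced no change beyond the scatter in this assay. Among the compounds with values here, with only that step as guidance, no step beyond the scatter is expected from compound 1 to compound 3 either, with both measured compounds sitting near the floor of the read-out.

Compound 3 is therefore expected to give about 4% in this assay, within a range from -6% to 14%, which means an expected step of a number 0.7 percentage points lower from compound 1 to compound 3 (within the scatter).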

Compound 3, a percentage reported as inhibition, at one concentration (the size of the read-out at that concentration, not a potency): 5.83%
Estimate against measurement, compound 3: 1.8 percentage points below; measured number inside the range.
By their numbers in this assay, from the lowest: compounds 2, 1 and 3 (each within the scatter of the next).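

In this assay the swap from naphthalen-1-yl to 3-(trifluoromethyl)phenyl on this aromatic carbon gives a number 1.1 percentage points higher from compound 1 to compound 3 (within the scatter) and the swap from 4-acetylphenyl to the same group gives a number 4.6 percentage points higher from compound 2 to compound 3 (within the scatter) in the same place. Neither step can be told apart from repeated-measurement noise, so this position now has three different aromatic groups that all read at the same low level of inhibition: one with two six-membered aromatic rings, and two with a single ring carrying a trifluoromethyl or an acetyl group at different ring positions. No measurement shown gives a reason for this flat result.

All three groups are built on aromatic rings of carbon only, so the compounds shown leave open whether a basic amine, a carboxylic acid or a morpholine ring on this carbon would lift the number clear of the scatter. They also leave open whether any change at this position can matter while the cyclohexyl group and the rest of the shared core stay as they are, since every compound here sits at a similarly low level.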